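This account rests on a few compounds, and the source may have more. Where it says the series, first, only, none or still open, it means among the compounds named here.

Compound 1, `CCCc1nc(C(C)(C)O)c(C(=O)NCCNCCO)n1Cc1ccc(-c2ccccc2C2=NNNN2)cc1`: in an ADME assay on a cell-free system (plasma, Rattus norvegicus, strain Sprague-Dawley) for metabolic stability, with a stated time of 30 min, tested at 50 mg/mL (a lower number here means that less of the compound is left, a higher number that more of the compound is left), compound 1 gives 98.9%.
Compound 2, `CCCc1nc(C(C)(C)O)c(C(=O)NCCCCCC[N+](=O)[O-])n1Cc1ccc(-c2ccccc2C2=NNNN2)cc1`: compound 2 gives 101%.
Compound 3, `CCCc1nc(C(C)(C)O)c(C(=O)OCCCCCCC(=O)OCC)n1Cc1ccc(-c2ccccc2C2=NNNN2)cc1`: compound 3 gives 81.1%.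

Compound 3 stands lowest of the three, as the steps of a number 17.8 percentage points lower from compound 1 to compound 3 (beyond the scatter) and a number 19.9 percentage points lower from compound 2 to compound 3 (beyond the scatter) show, both beyond the scatter. Compound 4, `CCCCCCCCOC(=O)c1c(C(C)(C)O)nc(CCC)n1Cc1ccc(-c2ccccc2C2=NNNN2)cc1`, differs from it by ethyl in place of ethoxycarbonyl on a saturated chain carbon, six bonds along the chain from an oxygen next to a carbonyl group. Going by the values given here, none of the measured steps touches this place: two exchange the whole group on the carbonyl carbon, and the third, a number 2.1 percentage points higher from compound 1 to compound 2 (within the scatter), swaps a chain-end group and stays within the scatter. That last step is the nearest guide, so the estimate is a step of a number 1.1 percentage points lower from compound 3 to compound 4 (within the scatter), within the scatter. Compound 4 is therefore expected to give 80%, between 62% and 97%.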

Compound 4, percent of the compound remaining: 90.2%
Estimate against measurement, compound 4: 10.2 percentage points below; low and high end bracket the measured number.
By their numbers in this assay, from the lowest: compounds 3, 4, 1 and 2 (each within the scatter of the next, the first and the last beyond it).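

In this assay, ethyl in place of ethoxycarbonyl at this place gives a number 9.1 percentage points higher from compound 3 to compound 4 (within the scatter), so exchanging this group on the chain does not separate the two compounds beyond the scatter. With octyloxy on the carbonyl carbon, the comparison with the (6-nitrohexyl)amino group gives a number 10.8 percentage points lower from compound 2 to compound 4 (beyond the scatter), which is beyond the scatter, while the comparison with the (2-((2-hydroxyethyl)amino)ethyl)amino group gives a number 8.7 percentage points lower from compound 1 to compound 4 (within the scatter), which is within it. Nothing available explains these steps. On these data alone, whether a carboxylic acid or a primary amide at this chain position would read the same remains open, as does the effect of a shorter chain.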